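The compounds below may be only part of what the source reports. "The series", "measured", "known", "first", "only" and "open" are said of these compounds alone.

Compound 1, `O=C(CCCCC1CCSS1)NO`: "not active" (no number reported)
Compound 2, `O=C(CCCCC(S)CCS)NO`: 17.7%

For the measured compounds named here, in a functional assay on NCI-H460 cells (Homo sapiens) for inhibition, read by MTT assay, with a stated time of 24 h, tested at 10 ug/mL (on this read-out lower numbers stand for less inhibition of growth and higher numbers for more inhibition of growth at the one concentration tested), compound 2 gives 17.7%, the only number available, since compound 1 is reported as "not active" (no number reported) with no figure attached. Compound 2 therefore has no numerical neighbour against which it can be ranked.

Compound 3, `O=C(CCCCC(S)CCS)Nc1ccccc1`, has not yet been measured in this assay. It carries phenyl in place of hydroxy on an amide-type nitrogen. Going by the values given here, no measured pair shows this change, so the data offer no direct guide to its size or direction. The expectation starts from compound 2 at 17.7% and allows for a reading of no activity.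

The expected change, a number 2.7 percentage points lower from compound 2 to compound 3 (within the scatter), is estimated to lie within the scatter, with no firm direction. For compound 3, the estimated value is 15%, with an expected range from 0% to 40%.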

Compound 3, percent growth inhibition at one concentration: 8.37%
Estimate against measurement, compound 3: 6.6 percentage points above; low and high end bracket the measured number.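

In this assay, for the compounds shown here, the exchange of hydroxy for phenyl on the amide-type nitrogen amounts to a number 9.3 percentage points lower from compound 2 to compound 3 (within the scatter), the first step that can be read. The nitrogen therefore carries either a single oxygen or a six-membered aromatic ring of carbon only, and the two readings cannot be told apart, so these compounds give no sign that the hydroxy is needed for the growth inhibition seen at the one concentration tested. Nothing measured here accounts for this result.

On these data alone, whether a benzyl group or a plain amide hydrogen on this nitrogen would read any differently stays open. So does whether a methoxy group on the phenyl would move the number beyond the scatter.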